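Compound 1 and an Untested 2-Aminophenyl Replacement

This account rests on a few compounds, and the source may have more. Where it says the series, first, only, none or still open, it means among the compounds named here.

Within the data shown here, in a functional assay on HCT-116 cells (Homo sapiens) for inhibition, with a stated time of 72 h (on this read-out higher numbers stand for weaker inhibition and lower numbers for stronger inhibition), compound 1 `NC1CCC(Nc2nc(NCc3ccc(-n4cccn4)cc3)c3ncn(C4CCCC4)c3n2)CC1` gives 320 nM, the lower of the two numbers measured so far. Compound 2 `NC1CCC(Nc2nc(NCc3ccc(-c4ccccc4O)cc3)c3ncn(C4CCCC4)c3n2)CC1` shows clearly weaker inhibition in this assay (4350 nM). Compound 3 `Nc1ccccc1CNc1nc(NC2CCC(N)CC2)nc2c1ncn2C1CCCC1` has not yet been measured. It differs from compound 1 by one change (2-aminophenyl in place of 4-(1H-pyrazol-1-yl)phenyl on a saturated chain carbon bound to a nitrogen on an aromatic ring): 2-aminophenyl in place of 4-(1H-pyrazol-1-yl)phenyl on a saturated chain carbon bound to a nitrogen on an aromatic ring.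

Among the measured compounds shown here, only one measured step bears on this change, and only indirectly. Putting 2-hydroxyphenyl in place of 1H-pyrazol-1-yl on an aromatic carbon gave a large step (a 14-fold higher number from compound 1 to compound 2 (1.13 log units; beyond the scatter)). That step alters the same group but is not the same replacement, so it offers a guide to direction and not an exact size. With compound 1 holding the lower number, a moderate move towards weaker inhibition is expected in this assay (a 4.1-fold higher number from compound 1 to compound 3 (0.61 log units; beyond the scatter)). The estimated value for compound 3 is 1300 nM, with an expected range from 350 nM to 5000 nM.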

Compound 3, half-maximal inhibitory concentration: 2300 nM
For compound 3 the middle estimate is 1.8-fold (0.25 log units) below the measured one, and the stated range covers the measured number.
By their numbers in this assay, from the lowest: compound 1; then compounds 3 and 2 (each within the scatter of the next).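

Exchanging the whole 4-(1H-pyrazol-1-yl)phenyl on the saturated chain carbon bound to a nitrogen on an aromatic ring for 2-aminophenyl gave a 7.2-fold higher number from compound 1 to compound 3 (0.86 log units; beyond the scatter), so the move towards weaker inhibition seen earlier with a replacement of the outer ring alone also appears when the entire group is replaced. Compound 1 therefore still holds the lowest number in this assay, while compound 3 at 2300 nM and compound 2 at 4350 nM lie within the scatter of each other, even though 2-aminophenyl carries one six-membered aromatic ring of carbon only and compound 2 retains a larger group at this place. Nothing available here explains why the number changes with this replacement.

The compounds shown leave open how much of the step belongs to the amine and how much to the loss of the five-membered aromatic ring. An unsubstituted phenyl or a 2-hydroxyphenyl on the same chain carbon would begin to separate these two contributions.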